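From tert-butyl to (2,6-dichlorophenyl)amino on the carbonyl

The source may report more compounds than this note shows. Statements on the series, on what has been measured and on what is new or still open speak of the compounds shown alone.

compound 1 `CC(C)C(=O)Nc1ncc(SCc2ncc(C(C)(C)C)o2)s1` gives 50 nM
compound 2 `CC(C)(C)C(=O)Nc1ncc(SCc2ncc(C(C)(C)C)o2)s1` gives 250 nM
compound 3 `CC(C)OC(=O)Nc1ncc(SCc2ncc(C(C)(C)C)o2)s1` gives 640 nM

These values come from a functional assay on A2780 cells (Homo sapiens) for cytotoxicity (a lower number here means a stronger inhibitor, a higher number a weaker inhibitor), and place compound 2 in the middle of the three, with a 5.0-fold higher number from compound 1 to compound 2 (0.70 log units; beyond the scatter) on one side. Compound 4 `CC(C)(C)c1cnc(CSc2cnc(NC(=O)Nc3c(Cl)cccc3Cl)s2)o1` has not yet been measured. It differs from compound 2 by (2,6-dichlorophenyl)amino in place of tert-butyl on a carbonyl carbon and so carries (2,6-dichlorophenyl)amino in place of tert-butyl on a carbonyl carbon.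

Two other measured steps changed the group on this carbonyl carbon. The large 13-fold higher number from compound 1 to compound 3 (1.11 log units; beyond the scatter) and the modest 2.6-fold higher number from compound 2 to compound 3 (0.41 log units; beyond the scatter) both went to a higher number. On that evidence, a modest step towards a higher number is expected here. Among the measured compounds shown here, no measured compound has an aromatic ring in this place, so the size of the step remains uncertain. The expected change is a 3.2-fold higher number from compound 2 to compound 4 (0.51 log units; beyond the scatter) and no more than an estimate. Compound 4 is expected at 800 nM with an estimated range of 150 nM to 4000 nM in this assay.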

Compound 4, half-maximal inhibitory concentration: 1500 nM
For compound 4 the middle estimate is 1.9-fold (0.27 log units) below the measured one; measured number inside the range.
By their numbers in this assay, from the lowest: compound 1; then compound 2; then compound 3; then compound 4.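

Among the compounds shown here, with (2,6-dichlorophenyl)amino, an aromatic ring now sits on the carbonyl carbon for the first time, and in this assay this change gives a 6.0-fold higher number from compound 2 to compound 4 (0.78 log units; beyond the scatter) and, against the isopropoxy group, a 2.3-fold higher number from compound 3 to compound 4 (0.37 log units; beyond the scatter). The widest step in the set is a 30-fold higher number from compound 1 to compound 4 (1.48 log units; beyond the scatter), so all three other groups on this carbonyl carbon, including the ring-bearing one, give higher numbers than isopropyl, and none of the compounds shown goes against this. Nothing available explains the rise in the number from tert-butyl to (2,6-dichlorophenyl)amino.

As far as these compounds go, the amino link, the aromatic ring and the two chlorines enter together in compound 4, so their separate shares in the step remain open. Also open, from the compounds shown here alone, is how plain phenylamino, or an ethyl or cyclopropyl group in place of isopropyl, would compare in this assay.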